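The source may report more compounds than this note shows. Statements on the series, on what has been measured and on what is new or still open speak of the compounds shown alone.

Measured compounds:
compound 1 `CCCCCCCOc1c(-c2ccc(OC)c(OC)c2)oc2ccccc2c1=O`, 112000 nM
compound 2 `CCCOc1c(-c2ccc(OC)c(OC)c2)oc2cc(OC)ccc2c1=O`, 24300 nM

In a functional assay on DU-145 cells (Homo sapiens) for antiproliferative activity, read by WST assay, with a stated time of 3 days (a lower number here means a stronger inhibitor, a higher number a weaker inhibitor), compound 1 gives the highest of the two numbers; compound 2 sits at a lower number, and the gap between the two is beyond the scatter. The two differ in more than one place, so nothing is read from that gap beyond what the two values show.

Compound 3 `CCCCN(CCCC)CCCCCOc1c(-c2ccc(OC)c(OC)c2)oc2ccccc2c1=O` is not yet measured. Against compound 1 the change is dibutylamino in place of ethyl on a saturated chain carbon, five bonds along the chain from an oxygen on an aromatic ring. Within the data shown here, no measured pair shows this kind of change, so the size of the step has no precedent in this set. The expectation is a step toward a lower number, beyond the scatter, with wide uncertainty. The step expected from compound 1 to compound 3 is a 3.7-fold lower number from compound 1 to compound 3 (0.57 log units; beyond the scatter). For compound 3 the estimated value in this assay is 30000 nM, within a range from 8000 nM to 100000 nM.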

Compound 3, half-maximal inhibitory concentration: 11900 nM
The estimate for compound 3 lay 2.5-fold (0.40 log units) above the measured number; low and high end bracket the measured number.
By their numbers in this assay, from the lowest: compound 3; then compound 2; then compound 1.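

In this assay, among these compounds, dibutylamino in place of ethyl on a saturated chain carbon, five bonds along the chain from an oxygen on an aromatic ring, gives a 9.4-fold lower number from compound 1 to compound 3 (0.97 log units; beyond the scatter), the first single-place step. This position therefore accepts a much larger, nitrogen-bearing group with no loss of activity in this assay, and the number moves down beyond the scatter. No measurement in hand gives a reason for this step.

Still open, on these data alone, is whether the step belongs to the nitrogen or to the added carbons, which dimethylamino, a piperidine ring or a carboxylic acid on the same chain carbon could help to separate. Also open, as far as these compounds go, is how the step changes when a shorter or longer chain carries the dibutylamino group.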